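Chloro for methoxy on a phthalazinone benzyl group

This account rests on a few compounds, and the source may have more. Where it says the series, first, only, none or still open, it means among the compounds named here.

Compound 1, `CCCCn1nc(Cc2ccc(Cl)cc2)c2ccccc2c1=O`: > 100000 nM
Compound 2, `COc1ccc(Cc2nn(C)c(=O)c3ccccc23)cc1`: < 100000 nM

Of the compounds shown here, two have been tested in a functional assay on aorta with Alpha-1D adrenergic receptor (Rattus norvegicus) as the target; on this read-out lower numbers stand for an effect already at smaller amounts and higher numbers for an effect only at larger amounts of compound. For compound 1 the result is a limit of the assay, > 100000 nM. For compound 2 the result is also a limit of the assay, < 100000 nM. Compound 2 therefore stands at the limit described as the limit of < 100000 nM in this assay, at which 1 of the 2 values shown sits, while compound 1 sits at the limit described as the limit of > 100000 nM in this assay, at which 1 of the 2 values shown sits. Neither value is a number, so the two compounds cannot be ranked against each other beyond the side of the limit on which each falls.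

Compound 3, `Cn1nc(Cc2ccc(Cl)cc2)c2ccccc2c1=O`, has not yet been measured. It differs from compound 2 by chloro in place of methoxy on an aromatic carbon. Among the measured compounds shown here, no step between measured compounds that share this change is available, so the size of the step is open. The step from compound 2 to compound 3 is expected to be a step that the limit leaves unreadable from compound 2 to compound 3. Compound 3 is estimated at 50000 nM, with a range from 10000 nM to 200000 nM.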

Compound 3, half-maximal effective concentration: 430 nM
Compound 3: the middle estimate sits 120-fold (2.07 log units) above what was measured; measured number below the stated range.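

In this assay, among the compounds shown here, compound 3 gives 430 nM, the only value that is a number and not a limit of the assay, so a compound with the chloro group at this place, para to a large group, does show an effect at a readable concentration. With the chloro group held fixed, hydrogen in place of propyl on a saturated chain carbon bound to an aromatic nitrogen gives an at least 230-fold lower number from compound 1 to compound 3 (2.36 log units; beyond the scatter), so in this pair the chain on the aromatic nitrogen has a large bearing on the read-out. The step for chloro in place of methoxy, by contrast, cannot be read, because compound 2 is held only at a limit of the assay: the limit of < 100000 nM in this assay, at which 1 of the 3 values shown sits.

From the compounds shown here alone, it therefore stays open whether chloro or methoxy gives the lower number at this place when the rest of the molecule is the same. Also open, going by these compounds, is how a fluoro or dimethylamino group in place of the chloro group, or an ethyl chain on the aromatic nitrogen, would read in this assay.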